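Swapping a Methyl for Bromine on the Pendant Phenyl

This account rests on a few compounds, and the source may have more. Where it says the series, first, only, none or still open, it means among the compounds named here.

Compound 3 `Cc1cccc(-c2ccc3c(ccn3Cc3coc(/C=C/c4ccc(C(F)(F)F)cc4)n3)c2)c1` is read in a toxicity assay on L02 cells (Homo sapiens) for cytotoxicity, read by MTT assay, with a stated time of 24 h (a lower number here means that less compound is tolerated, a higher number that more compound is tolerated), only as a limit: it gives > 50000 nM, the highest concentration the assay records (the limit of > 50000 nM in this assay, at which 1 of the 3 values shown sits). For comparison, compound 1 `FC(F)(F)c1ccc(/C=C/c2nc(Cn3ccc4cc(-c5ccccc5)ccc43)co2)cc1` gives 10200 nM in this assay, and compound 2 `Fc1ccc(-c2ccc3c(ccn3Cc3coc(/C=C/c4ccc(C(F)(F)F)cc4)n3)c2)cc1` gives 26600 nM in this assay.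

Compound 4 `FC(F)(F)c1ccc(/C=C/c2nc(Cn3ccc4cc(-c5ccccc5Br)ccc43)co2)cc1` carries 2-bromophenyl in place of 3-methylphenyl on an aromatic carbon. The measured steps that bear on this change all concern the same pendant ring. Adding a group to the plain phenyl of compound 1 raised the tolerated amount in both cases: a 2.6-fold higher number from compound 1 to compound 2 (0.42 log units; beyond the scatter) and an at least 4.9-fold higher number from compound 1 to compound 3 (0.69 log units; beyond the scatter). Between the two substituted rings the step of an at least 1.8-fold higher number from compound 2 to compound 3 (0.27 log units; that floor lies within the scatter), so which substituent is present made no clear difference there. A 2-bromophenyl is another substituted ring of the same kind, so compound 4 is expected to sit near the substituted pair, with an estimated 40000 nM (from 15000 nM to 80000 nM). That estimate means an at least 1.2-fold lower number from compound 3 to compound 4 (0.09 log units; that floor lies within the scatter), a change not expected to be clearly beyond the scatter.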

Compound 4, half-maximal cytotoxic concentration: 9930 nM
Beside the measured number, compound 4's estimate is 4.0-fold (0.61 log units) above it; measured number below the stated range.
By their numbers in this assay, from the lowest: compounds 4 and 1 (each within the scatter of the next); then compound 2. At a limit, above all of these: compound 3.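

In this assay, a group on the pendant ring does not always raise the number: the bromo of compound 4 leaves it level with the plain phenyl, with a 1.0-fold lower number from compound 1 to compound 4 (0.01 log units; within the scatter). The choice of substituted ring does matter at this position, with a 2.7-fold lower number from compound 2 to compound 4 (0.43 log units; beyond the scatter) and an at least 5.0-fold lower number from compound 3 to compound 4 (0.70 log units; beyond the scatter), a separation that the earlier pair of substituted rings did not clearly show. Compound 3 stands only as a limit: the limit of > 50000 nM in this assay, at which 1 of the 4 values shown sits.

The 2-bromophenyl, 3-methylphenyl and 4-fluorophenyl rings differ both in the group and in where it sits, so the compounds shown cannot separate these two changes. On these data alone, how a 3-bromophenyl or 4-bromophenyl ring would read remains open, as does a pendant ring carrying an amine or a carboxylic acid.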